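Acetyl in place of fluoro on a shared imidazopyrazine-bearing scaffold

This account rests on a few compounds, and the source may have more. Where it says the series, first, only, none or still open, it means among the compounds named here.

Compound 1: `c1ccc(-c2cn3ccnc3c(-c3ccc4ncn(C5CCCCC5)c4c3)n2)cc1`, 36.5% in a functional assay on SK-MEL-5 cells (Homo sapiens) for inhibition, read by sulforhodamine B assay, with a stated time of 48 h, tested at 10 uM; a higher number here means more inhibition at the concentration tested (going by the name of the read-out), a lower number less inhibition
Compound 2: `Fc1ccc(-c2cn3ccnc3c(-c3ccc4ncn(C5CCCCC5)c4c3)n2)cc1`, 7.36% in this assay

For the measured compounds named here, compound 2 stands at the lower of the two numbers measured so far; its nearest neighbour is compound 1, and the step of a number 29.1 percentage points lower from compound 1 to compound 2 (beyond the scatter) lies beyond the scatter. Compound 3, `CC(=O)c1ccc(-c2cn3ccnc3c(-c3ccc4ncn(C5CCCCC5)c4c3)n2)cc1`, has not yet been measured. It differs from compound 2 by acetyl in place of fluoro on an aromatic carbon. Going by the values given here, no measured step bears directly on this exchange: the only step in hand, a number 29.1 percentage points lower from compound 1 to compound 2 (beyond the scatter), concerns fluoro against hydrogen, not fluoro against acetyl, so it offers no more than a sense of how far a single change at this position has moved the number. The direction of the new step is open. Compound 3 is therefore expected to give 18%, with a range from -5% to 45%, which means an expected step of a number 10.6 percentage points higher from compound 2 to compound 3 (beyond the scatter).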

Compound 3, a percentage reported as inhibition, at one concentration (the size of the read-out at that concentration, not a potency): 24.8%
Estimate against measurement, compound 3: 6.8 percentage points below; low and high end bracket the measured number.
By their numbers in this assay, from the lowest: compound 2; then compound 3; then compound 1.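

In this assay the change from 4-fluorophenyl to 4-acetylphenyl gives the step of a number 17.4 percentage points higher from compound 2 to compound 3 (beyond the scatter) and so shows that the number at this position depends on which group is present, while the step of a number 11.7 percentage points lower from compound 1 to compound 3 (beyond the scatter) places acetyl short of hydrogen. Among these compounds, then, both fluoro and acetyl give lower numbers than the unsubstituted phenyl, with acetyl lying between the other two. Nothing available here explains why the groups differ.

For the compounds shown here, with only two groups in place of hydrogen, these compounds establish no trend at this position. They leave open whether an amine, a carboxylic acid or a methoxy group there would match or exceed the unsubstituted phenyl, and whether a longer chain ending in a ketone would follow acetyl.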